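The source may hold more compounds than are shown below. What is called first, only, known or untested is meant among the compounds shown, and "the series" means these compounds.

Working notes on the series.

Going by the values given here, compound 2 `COc1ccc(Cc2nn3cc(-c4cccc(N)c4)nc3s2)cc1` carries the highest number of the two measured so far: in a functional assay on FM3A cells (Mus musculus) for inhibition, read by cell counting, with a stated time of 2 days (on this read-out lower numbers stand for stronger inhibition and higher numbers for weaker inhibition), compound 2 gives 100000 nM. Among the compounds with values here, its nearest neighbour is compound 1 `Nc1cccc(-c2cn3nc(CCc4ccccc4)sc3n2)c1`, which in this assay gives 29000 nM; the one measured step, a 3.4-fold higher number from compound 1 to compound 2 (0.54 log units; beyond the scatter), is a modest weakening that lies beyond the scatter.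

Compound 3 `COc1cccc(Cc2nn3cc(-c4cccc(N)c4)nc3s2)c1` is not yet measured. It differs from compound 2 in one place: 3-methoxyphenyl in place of 4-methoxyphenyl on a saturated chain carbon bound to an aromatic carbon. The two compounds have the same atoms, joined differently.

Within the data shown here, no measured step bears on this change. The only step shown, a 3.4-fold higher number from compound 1 to compound 2 (0.54 log units; beyond the scatter), concerns the entry of the methoxyphenyl group itself, not the position of its methoxy group, so it gives no direction for the move from 4-methoxyphenyl to 3-methoxyphenyl. Among the measured compounds shown here, with no comparable precedent, no step beyond the scatter is expected in this assay in either direction, and the value of compound 2 is taken as the anchor.

Compound 3 is therefore expected to give about 90000 nM in this assay, with a range of 30000 nM to 200000 nM; this estimate implies a step of a 1.1-fold lower number from compound 2 to compound 3 (0.05 log units; within the scatter).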

Compound 3, half-maximal inhibitory concentration: 10000 nM
Estimate against measurement, compound 3: 9.0-fold (0.95 log units) above; the whole stated range lies above it.
By their numbers in this assay, from the lowest: compound 3; then compound 1; then compound 2.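

In this assay, moving the methoxy group alone changes the result: 3-methoxyphenyl in place of 4-methoxyphenyl on a saturated chain carbon bound to an aromatic carbon gives a 10-fold lower number from compound 2 to compound 3 (1.00 log units; beyond the scatter), so this place responds to where the methoxy group stands and not only to whether it is present. The earlier step suggested that a methoxyphenyl group here was a loss against benzyl, but a 2.9-fold lower number from compound 1 to compound 3 (0.46 log units; beyond the scatter) runs the other way, so that loss holds for 4-methoxyphenyl and not for methoxyphenyl groups in general. Nothing at hand explains the difference between the two methoxyphenyl groups.

Whether the gain belongs to the methoxy group itself stays open, since the compounds shown include no 2-methoxyphenyl, 3-hydroxyphenyl or 3-chlorophenyl group on this saturated chain carbon. Going by these compounds, the amine on the aromatic ring is also the same in all three compounds, so it remains unknown whether this order would hold with an amide or a carboxylic acid in its place.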